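The compounds below may be only part of what the source reports. "The series", "measured", "known", "first", "only" and "open" are said of these compounds alone.

Measured in an ADME assay on HFF cells (Homo sapiens) for cytotoxicity, read by neutral red uptake; a lower number here means that less compound is tolerated, a higher number that more compound is tolerated:

- Compound 1 `Nc1nc2c(ncn2/C=C2/C[C@@H]2[C@@H](O)CO)c(=O)[nH]1`: > 300000 nM
- Compound 2 `Nc1ncnc2c1ncn2/C=C1/C[C@@H]1[C@H](O)CO`: > 300000 nM
- Compound 3 `Nc1ncnc2c1ncn2/C=C1\C[C@@H]1[C@@H](O)CO`: > 300000 nM

Compound 1 stands at > 300000 nM, which is a limit of the assay and not a number. It gives no exact starting point, and the other measured compounds offer none either, as the record shows: the limit of > 300000 nM in this assay, at which 3 of the 3 values shown sit.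

Compound 4 `Nc1nc2c(ncn2/C=C2/C[C@H]2[C@@H](O)CO)c(=O)[nH]1` keeps the atoms and bonds of compound 1: the two compounds have the same atoms and bonds and differ only in configuration as drawn: 1 of 3 stereo elements differ; a stereocentre at a saturated ring carbon is drawn S in compound 1 and R in compound 4.

The nearest measured comparison is a step that the two limits leave unreadable from compound 2 to compound 3. It also involves configuration, as shown by the fact that compounds 2 and 3 differ only in the configuration as drawn, but the stereocentre there sits at a saturated chain carbon and a double bond differs as well. It therefore gives no measured size for this change at a saturated ring carbon.

With all three configurations measured so far reported only as limits, no step beyond the usual scatter is expected in this assay. The expected step is a number no higher from compound 1 to compound 4 (the limit leaves the size open). Compound 4 is most likely to be reported as a limit too. For compound 4, the estimated value is 300000 nM, with an expected range from 100000 nM to 400000 nM.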

Compound 4, half-maximal cytotoxic concentration: 299000 nM
For compound 4 the middle estimate is 1.0-fold (0.00 log units) above the measured one, within the range that was stated.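

In this assay, among the compounds shown here, compound 4 gives 299000 nM, the first exact number in this set, which shows that a compound with the R configuration at this saturated ring carbon can be given a measured value. Compound 1 stands at > 300000 nM, which is a limit of the assay. For this change in configuration the data give a number no higher from compound 1 to compound 4 (the limit leaves the size open), and its size cannot be read. Most of the set still sits at that limit: the limit of > 300000 nM in this assay, at which 3 of the 4 values shown sit.

On these data alone, it remains open whether the same change at the saturated ring carbon would give a number on the core of compound 2. As far as these compounds go, it also remains open how the value would respond if an amine, a carboxylic acid or a longer chain replaced the hydroxyl-bearing chain.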